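Aryl Swap on a Shared Core: Chloro to Fluoro

This account rests on a few compounds, and the source may have more. Where it says the series, first, only, none or still open, it means among the compounds named here.

Compound 2 `COc1cc(-n2cnc3ccc(-c4cccc(Cl)c4)cc32)cc(OC)c1OC` carries a 3-chlorophenyl on an aromatic carbon of the shared core. In a functional assay on MCF7 cells (Homo sapiens) for antiproliferative activity, read by MTT assay, with a stated time of 72 h (on this read-out lower numbers stand for stronger inhibition and higher numbers for weaker inhibition), compound 2 gives 3120 nM, the higher of the two numbers in hand. Compound 1 `COc1ccccc1-c1ccc2ncn(-c3cc(OC)c(OC)c(OC)c3)c2c1`, bearing a 2-methoxyphenyl instead, gives 1750 nM in this assay, and the step of a 1.8-fold higher number from compound 1 to compound 2 (0.25 log units; within the scatter) stays within the scatter. Compound 3 `COc1cc(-c2ccc3ncn(-c4cc(OC)c(OC)c(OC)c4)c3c2)cc(OC)c1OC` reaches only a limit in this assay, namely > 10000 nM (the limit of > 10000 nM in this assay, at which 1 of the 3 values shown sits). Compound 4 `COc1cc(-n2cnc3ccc(-c4ccc(F)cc4)cc32)cc(OC)c1OC` differs from compound 2 in one place: 4-fluorophenyl in place of 3-chlorophenyl on an aromatic carbon. Among the compounds with values here, the single measured step that bears on such an aryl exchange, a 1.8-fold higher number from compound 1 to compound 2 (0.25 log units; within the scatter), remained within the scatter, so the expected step of a 1.2-fold lower number from compound 2 to compound 4 (0.10 log units; within the scatter) is likewise estimated to stay within the scatter. Compound 4 is therefore estimated at 2500 nM, between 1000 nM and 7000 nM.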

Compound 4, half-maximal inhibitory concentration: 1770 nM
For compound 4 the middle estimate is 1.4-fold (0.15 log units) above the measured one, within the range that was stated.
By their numbers in this assay, from the lowest: compounds 1, 4 and 2 (each within the scatter of the next). At a limit, above all of these: compound 3.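

In this assay, putting a 4-fluorophenyl in place of the 3-chlorophenyl gives a 1.8-fold lower number from compound 2 to compound 4 (0.25 log units; within the scatter), and putting it in place of the 2-methoxyphenyl gives a 1.0-fold higher number from compound 1 to compound 4 (0.00 log units; within the scatter). Three differently substituted phenyl groups on this aromatic carbon now lie within the scatter of one another, and moving the halogen-bearing group's substituent and changing the halogen together shows no step beyond it. No measured property given here bears on these steps. The compounds shown leave open whether an amine, a carboxylic acid or a longer chain on this carbon would give a step beyond the scatter.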